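Fluoro in Place of Methoxy at a Limit

A few compounds are considered here, and "the series" means these few. Any claim that something is new, unique, unknown or untested is made for them only; others in the source may bear on it.

In a functional assay on Raji cells (Homo sapiens) for cytotoxicity, with a stated time of 72 h (on this read-out lower numbers stand for an effect already at smaller amounts and higher numbers for an effect only at larger amounts of compound), compound 1 `C=C[C@@](C)(/C=C/c1ccc(Nc2ccccc2)cc1)CCC=C(C)C` gives only a limit, > 26000 nM. Compound 2 `C=C[C@@](C)(/C=C/c1ccc(Nc2ccc(OC)cc2)cc1)CCC=C(C)C` also gives only a limit, > 26000 nM. Compound 3 `C=C[C@@](C)(/C=C/c1ccc(Nc2ccc(OC)c(OC)c2)cc1)CCC=C(C)C` stands at a limit too, > 26000 nM, so it has no number of its own. The whole set sits at the limit of > 26000 nM in this assay, at which 3 of the 3 values shown sit.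

Compound 4 `C=C[C@@](C)(/C=C/c1ccc(Nc2ccc(OC)c(F)c2)cc1)CCC=C(C)C` carries fluoro in place of methoxy on an aromatic carbon, ortho to a methoxy group: fluoro in place of methoxy on an aromatic carbon. Among the measured compounds shown here, two measured steps bear on this, a step that the two limits leave unreadable from compound 1 to compound 2 and a step that the two limits leave unreadable from compound 2 to compound 3. Neither gives a size or a direction, so no readable change is expected in this assay. The expected move is a step that the limit leaves unreadable from compound 3 to compound 4, with its direction unknown. Compound 4 is estimated at 30000 nM, within an expected range of 12000 nM to 60000 nM, and will most probably be reported as a limit again.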

Compound 4, half-maximal effective concentration: > 26000 nM
Compound 4 ended at the assay's limit; the forecaster's own chance of this, stated with the estimate: 85%; the middle value does not contradict the limit.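

No step can be read between compound 1, compound 2, compound 3 and compound 4 in this assay, as each gives only a limit: the limit of > 26000 nM in this assay, at which 4 of the 4 values shown sit. The compounds shown leave open whether any of these replacements changes the effect, and in which direction.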